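This account rests on a few compounds, and the source may have more. Where it says the series, first, only, none or still open, it means among the compounds named here.

Working notes on the furan-core amides, cytotoxicity series.

Three members of the series have been run in a functional assay on HeLa cells (Homo sapiens) for cytotoxicity, read by MTT assay, with a stated time of 24 h; on this read-out higher numbers stand for weaker inhibition and lower numbers for stronger inhibition. Compound 1, `C=CC1=C(C(=O)NCCCCC)C(c2ccc(OC)cc2)OC1`, carries a pentylamino amide and a methoxy group on the aryl ring. In this assay compound 1 gives only a limit of the assay, > 100000 nM. Compound 2, `C=CC1=C(C(=O)Nc2ccccc2)C(c2ccc(Cl)c(Cl)c2)OC1`, pairs an anilide with a dichlorinated aryl ring. In this assay compound 2 likewise returns a limit, > 100000 nM. Compound 3, `C=CC1=C(C(=O)NCCCCC)C(c2ccc(F)cc2)OC1`, keeps the pentylamino amide of compound 1 and carries fluoro on the aryl ring. In this assay compound 3 again sits at a limit, > 100000 nM. For the measured compounds named here, the single one-place step on record, a step that the two limits leave unreadable from compound 1 to compound 3, cannot be read in size, since both ends are limits; the limit of > 100000 nM in this assay, at which 3 of the 3 values shown sit, is where every value so far sits.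

The next member, compound 4, `C=CC1=C(C(=O)NCc2ccccc2)C(c2ccc(F)cc2)OC1`, differs from compound 3 by phenyl in place of butyl on a saturated chain carbon bound to an amide-type nitrogen. Going by the values given here, no measured step bears on this change, and the fluoro-aryl end of the molecule is unchanged from compound 3. With compound 3 at > 100000 nM and nothing else in the series escaping the limit, compound 4 is expected to remain at or near the limit, an expected step of a number no higher from compound 3 to compound 4 (the limit leaves the size open). The estimate for compound 4 is therefore 100000 nM, within 30000 nM to 300000 nM, most probably reported as a limit only.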

Compound 4, half-maximal inhibitory concentration: > 100000 nM
Compound 4: a limit, no number; the forecaster's own chance of this, stated with the estimate: 80%; the middle value sits exactly at the limit.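

As far as these compounds go, compound 3 and compound 4 both return only limits, so no step can be read between them, and the size of the change from butyl to phenyl stays unknown. The compounds shown leave open whether any change to the amide side chain or the aryl ring would give a readable number: the limit of > 100000 nM in this assay, at which 4 of the 4 values shown sit.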